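Sulfonyl tail variation on the shared core

The source may hold more compounds than are shown below. What is called first, only, known or untested is meant among the compounds shown, and "the series" means these compounds.

Values in an assay on isolated protein for inhibition of serine/threonine-protein kinase Nek1 (Homo sapiens), read by TR-FRET, with a stated time of 30 min (on this read-out lower numbers stand for stronger inhibition and higher numbers for weaker inhibition), for the three measured compounds:
compound 1 `CCN(CC)CCNS(=O)(=O)c1ccc(-c2ccnc3[nH]ccc23)cc1` gives 10000 nM
compound 2 `O=S(=O)(NCCN1CCCCC1)c1ccc(-c2ccnc3[nH]ccc23)cc1` gives 6600 nM
compound 3 `CC(C)(O)CNS(=O)(=O)c1ccc(-c2ccnc3[nH]ccc23)cc1` gives 5800 nM

Compound 2 holds the second highest of the three numbers. The step of a 1.1-fold lower number from compound 2 to compound 3 (0.06 log units; within the scatter) and the step of a 1.5-fold lower number from compound 1 to compound 2 (0.18 log units; within the scatter) both stay within the scatter, as does a 1.7-fold lower number from compound 1 to compound 3 (0.24 log units; within the scatter). All three measured changes sit on the chain attached to the sulfonamide nitrogen, and none of them moves the number beyond the scatter.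

Compound 4 `CN1CCN(S(=O)(=O)c2ccc(-c3ccnc4[nH]ccc34)cc2)CC1` is the next compound: 4-methylpiperazin-1-yl in place of (2-(piperidin-1-yl)ethyl)amino on a sulfonyl sulfur. For the measured compounds named here, no measured step alters the group on the sulfonyl sulfur itself, so no step bears on this change directly. Going by the values given here, the only guidance is that varying the tail has so far left the number unmoved, so a step within the scatter is expected, a 1.1-fold higher number from compound 2 to compound 4 (0.03 log units; within the scatter). Compound 4 is accordingly estimated at 7000 nM, with a range from 2500 nM to 20000 nM.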

Compound 4, half-maximal inhibitory concentration: > 10000 nM
Compound 4 was reported as a limit (the forecaster's own chance of this, stated with the estimate: 25%); middle value at least 1.4-fold (0.15 log units) away from the limit.
By their numbers in this assay, from the lowest: compounds 3, 2 and 1 (each within the scatter of the next).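

Compound 4 is a limit and not a number, the only one among the four: the limit of > 10000 nM in this assay, at which 1 of the 4 values shown sits.

For the compounds shown here, this is the first change on the sulfonyl sulfur itself, with 4-methylpiperazin-1-yl, which has 0 hydrogen-bond donors, in place of amino tails that have 1, yet in this assay the two readable steps, an at least 1.5-fold higher number from compound 2 to compound 4 (0.18 log units; that floor lies within the scatter) and an at least 1.7-fold higher number from compound 3 to compound 4 (0.23 log units; that floor lies within the scatter), have floors within the scatter, so they neither establish a real rise nor rule one out. The third step is a number no lower from compound 1 to compound 4 (the limit leaves the size open) and its size cannot be read.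

As far as these compounds go, whether this change at the sulfonyl sulfur truly moves the number therefore stays open. Also open, from the compounds shown here alone, is whether morpholin-4-yl or an unsubstituted amino group on the sulfonyl sulfur would give a value that can be compared with compound 2.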